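Clearance step from compound 3 to compound 4

A few compounds are considered here, and "the series" means these few. Any claim that something is new, unique, unknown or untested is made for them only; others in the source may bear on it.

In an in vivo ADME assay on the whole organism (plasma) for pharmacokinetics, with Rattus norvegicus as the target, at a dose of 5 mg/kg by the intravenous route (on this read-out higher numbers stand for fast clearance and lower numbers for slow clearance), compound 3 `CCC(CSC(CCc1ccccc1S(C)(=O)=O)c1cccc(OCc2ccc3ccc(Cl)cc3n2)c1)C(=O)O` gives 35 mL/min/kg, the second highest of three numbers. Compound 1 `CCNC(=O)c1ccccc1CCC(SCC(CC)C(=O)O)c1cccc(OCc2ccc3ccc(Cl)cc3n2)c1` stands highest at 106 mL/min/kg, and compound 2 `CCC(CSC(CCc1ccccc1C(=O)O)c1cccc(OCc2ccc3ccc(Cl)cc3n2)c1)C(=O)O` stands lowest at 8.8 mL/min/kg.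

Compound 4 `CCC(CSC(CCc1ccccc1-c1nnnn1C)c1cccc(OCc2ccc3ccc(Cl)cc3n2)c1)C(=O)O` has 1-methyl-1H-tetrazol-5-yl in place of methylsulfonyl on an aromatic carbon.

Three measured steps change the same substituent. The two that end at methylsulfonyl are modest, a 3.0-fold lower number from compound 1 to compound 3 (0.48 log units; beyond the scatter) and a 4.0-fold higher number from compound 2 to compound 3 (0.60 log units; beyond the scatter), while the one between the two carbonyl groups is large, a 12-fold lower number from compound 1 to compound 2 (1.08 log units; beyond the scatter). For the measured compounds named here, no measured compound carries a tetrazole, so these steps bound the estimate only loosely. The entering group, like methylsulfonyl, has no net charge, whereas compound 2 with 8.8 mL/min/kg is the carboxy member and compound 1 with 106 mL/min/kg is the neutral amide.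

The expected change is no step beyond the scatter, a 1.1-fold higher number from compound 3 to compound 4 (0.06 log units; within the scatter), with a slight lean upward toward the neutral amide. For compound 4 the estimated clearance is 40 mL/min/kg, with an expected range of 16 mL/min/kg to 90 mL/min/kg.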

Compound 4, clearance: 18 mL/min/kg
Beside the measured number, compound 4's estimate is 2.2-fold (0.35 log units) above it; the measured number falls inside the stated range.
By their numbers in this assay, from the lowest: compound 2; then compounds 4 and 3 (each within the scatter of the next); then compound 1.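

In this assay, a second group with no net charge on this aromatic carbon, now a five-membered aromatic ring, leaves the read-out within the scatter, with a 1.9-fold lower number from compound 3 to compound 4 (0.29 log units; within the scatter), so methylsulfonyl and 1-methyl-1H-tetrazol-5-yl are not separated here. Lack of net charge does not by itself set the level, since the uncharged ethylcarbamoyl group of compound 1 goes against any such grouping, with a 5.9-fold lower number from compound 1 to compound 4 (0.77 log units; beyond the scatter), while the carboxy group stays apart on the other side, with a 2.0-fold higher number from compound 2 to compound 4 (0.31 log units; beyond the scatter). No measurement is at hand that would explain these differences.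

Open, going by these compounds, is where a primary amine or a methyl ester on this aromatic carbon would fall relative to compound 2 and compound 1. Also open, on these data alone, is whether removing the methyl from the tetrazole, leaving 1H-tetrazol-5-yl, would keep the number with that of compound 4.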